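The compounds below may be only part of what the source reports. "The series", "measured", "known", "first", "only" and "open" are said of these compounds alone.

Measured so far:
compound 1 `c1ccc(CNCCCCN(C[C@H]2Cc3ccccc3CN2)[C@H]2CCCc3cccnc32)cc1`: 20.1 nM
compound 2 `c1ccc2c(c1)CN[C@@H](CN(CCCCNCC1CCOCC1)[C@H]1CCCc3cccnc31)C2`: 52.9 nM
compound 3 `c1ccc2c(c1)CN[C@@H](CN(CCCCNCC1CCNCC1)[C@H]1CCCc3cccnc31)C2`: 36.5 nM

In a functional assay on cells for antagonist activity at C-X-C chemokine receptor type 4 (Homo sapiens), read by fluorescence and calcium flux, with stated times of 25 min and 90 s (on this read-out higher numbers stand for weaker inhibition and lower numbers for stronger inhibition), compound 3 stands second highest of the three numbers. The steps of a 1.4-fold lower number from compound 2 to compound 3 (0.16 log units; within the scatter) and a 1.8-fold higher number from compound 1 to compound 3 (0.26 log units; within the scatter) both lie within the scatter, so no order among the three can be drawn from these values; only a 2.6-fold higher number from compound 1 to compound 2 (0.42 log units; beyond the scatter) reaches beyond the scatter, and that step is modest.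

Compound 4 `c1ccc2c(c1)CN[C@@H](CN(CCCCNC1CCOCC1)[C@H]1CCCc3cccnc31)C2` differs from compound 3 in one place: oxan-4-yl in place of (piperidin-4-yl)methyl on an amine nitrogen. Within the data shown here, two measured steps bear on this. The oxygen-for-nitrogen exchange in the ring is covered by a 1.4-fold lower number from compound 2 to compound 3 (0.16 log units; within the scatter), which is within the scatter; the introduction of oxan-4-yl itself is covered by a 2.6-fold higher number from compound 1 to compound 2 (0.42 log units; beyond the scatter), which is modest. Among the measured compounds shown here, the loss of the chain carbon between the amine nitrogen and the ring has no measured counterpart here, which widens the uncertainty. The expected step in this assay is therefore small, a 1.6-fold higher number from compound 3 to compound 4 (0.22 log units; within the scatter), towards a somewhat higher number at most. Compound 4 is expected to give 60 nM, with a range from 25 nM to 150 nM.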

Compound 4, half-maximal inhibitory concentration: 29.4 nM
Estimate against measurement, compound 4: 2.0-fold (0.31 log units) above; the measured number falls inside the stated range.
By their numbers in this assay, from the lowest: compounds 1, 4, 3 and 2 (each within the scatter of the next, the first and the last beyond it).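

In this assay, oxan-4-yl set directly on the amine nitrogen stays within the scatter of all three earlier groups: (piperidin-4-yl)methyl (a 1.2-fold lower number from compound 3 to compound 4 (0.09 log units; within the scatter)), (oxan-4-yl)methyl (a 1.8-fold lower number from compound 2 to compound 4 (0.26 log units; within the scatter)) and benzyl (a 1.5-fold higher number from compound 1 to compound 4 (0.17 log units; within the scatter)). The earlier compounds shown here all carried a chain carbon on this amine nitrogen, so compound 4 adds that a ring attached directly there also gives a value within the scatter of each of them. The step beyond the scatter (a 2.6-fold higher number from compound 1 to compound 2 (0.42 log units; beyond the scatter)) is not repeated when oxan-4-yl itself replaces benzyl, and no measurement at hand explains these values.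

Still open, as far as these compounds go, is whether a longer chain between the amine nitrogen and the oxan-4-yl ring would keep the number within the scatter. Also open, from the compounds shown here alone, is whether a carboxylic acid on that ring would do so.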